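The source may hold more compounds than are shown below. What is called first, only, known or untested is meant among the compounds shown, and "the series" means these compounds.

The series rests on one shared core carrying a hydroxyl and an aryl group. Compound 1 `Cc1ccc2c(O)cc(-c3cccc(Cl)c3)nc2n1` is measured in a functional assay on PC-3 cells (Homo sapiens) for antiproliferative activity (a lower number here means a stronger inhibitor of growth, a higher number a weaker inhibitor of growth), where compound 1 gives only a limit of the assay, > 100000 nM. Compound 2 `Cc1cc(C)c2c(O)cc(-c3cccc(Cl)c3)nc2n1` differs from compound 1 by a single change, (methyl in place of hydrogen on an aromatic carbon), and in this assay compound 2 gives 27.5 nM. That step, an at least 3600-fold lower number from compound 1 to compound 2 (3.56 log units; beyond the scatter), is the largest in the set, its lower bound set because compound 1 sits at the limit of > 100000 nM in this assay, at which 1 of the 3 values shown sits. Compound 3 `Cc1ccc2c(O)cc(-c3ccc4ccccc4c3)nc2n1` carries a different aryl group on the core of compound 1; how its core differs from that of compound 1 is not broken down here. In this assay compound 3 gives 2630 nM. Compound 4 `Cc1cc(C)c2c(O)cc(-c3ccc4ccccc4c3)nc2n1` is not yet measured; it stands to compound 3 as compound 2 stands to compound 1, through the same change, (methyl in place of hydrogen on an aromatic carbon). Since compound 3 already gives 2630 nM, a somewhat smaller but still large drop is expected, a 180-fold lower number from compound 3 to compound 4 (2.24 log units; beyond the scatter). Compound 4 is thus estimated to give 15 nM, between 2 nM and 150 nM.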

Compound 4, concentration for 50% growth inhibition: 5500 nM
Beside the measured number, compound 4's estimate is 370-fold (2.56 log units) below it; the whole stated range lies below it.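

Carried to the core of compound 3, the methyl in place of hydrogen on an aromatic carbon gives a 2.1-fold higher number from compound 3 to compound 4 (0.32 log units; beyond the scatter) in this assay, a modest step, and it does not repeat what the same change did on the core of compound 1: the same change on two cores in this assay, an at least 3600-fold lower number (3.56 log units; beyond the scatter) from compound 1 to compound 2 and a 2.1-fold higher number (0.32 log units; beyond the scatter) from compound 3 to compound 4, at least 7600-fold (3.88 log units) apart, beyond the scatter of two such steps

The earlier step is only a lower bound, as compound 1 stands at a limit of the assay, which is not a number: the limit of > 100000 nM in this assay, at which 1 of the 4 values shown sits.

These two pairs show that the outcome of this change cannot be assumed to carry from one core to another in this series, but they do not show why the two differ or which outcome is the more usual one.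

The compounds shown leave open whether other aryl groups on the shared core would follow the pair of compound 1 and compound 2 or that of compound 3 and compound 4. They also leave open how an ethyl group, a methoxy group or an amine in the same place would compare with the methyl.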